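Taking the nitro group off compound 3

The source may report more compounds than this note shows. Statements on the series, on what has been measured and on what is new or still open speak of the compounds shown alone.

Of the compounds shown here, three have so far been measured in a physicochemical assay for lipophilicity, read by HPLC; a lower number here means a more polar compound, a higher number a more lipophilic compound. Compound 1 (`CCCn1cc(C(=O)NCc2ccccc2)c(=O)c2cc(F)c(N3CCC(C(N)=O)CC3)cc21`) gives 2.4 and compound 2 (`NC(=O)C1CCN(c2cc3c(cc2F)c(=O)c(C(=O)NCc2ccccc2)cn3C2CC2)CC1`) gives 2.4 while compound 3 (`CCCCn1cc(C(=O)NCc2ccc([N+](=O)[O-])cc2)c(=O)c2cc(F)c(N3CCC(C(N)=O)CC3)cc21`) gives 2.4 and so stands level with both. Compound 4 (`CCCCn1cc(C(=O)NCc2ccccc2)c(=O)c2cc(F)c(N3CCC(C(N)=O)CC3)cc21`) is compound 3 with hydrogen in place of nitro on an aromatic carbon, para to a large group (hydrogen in place of nitro on an aromatic carbon), which turns 4-nitrobenzyl into benzyl. For the measured compounds named here, the only measured step between compounds that differ in one place is no change at the digits printed from compound 1 to compound 2 (within the scatter) and it lies on an aromatic nitrogen, so it bears on this change only loosely. Going by the values given here, that step stayed within the scatter, but no measured step isolates the nitro group. Compound 4 combines the butyl chain of compound 3 at 2.4 with the unsubstituted benzyl of compound 1 at 2.4 and neither value settles the outcome. On this thin evidence, a small upward step is expected (a number 0.20 log units higher from compound 3 to compound 4 (within the scatter)) and it may not clear the scatter. The estimate for compound 4 is 2.6 with an expected range from 2.3 to 3 for the measurement still to come.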

Compound 4, partition coefficient: 2.4
Compound 4: middle estimate off by 0.20 log units, on the high side; the measured number falls inside the stated range.
By their numbers in this assay, from the lowest: compounds 1, 2, 3 and 4 (each within the scatter of the next).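

For the compounds shown here, exchanging 4-nitrobenzyl for benzyl gives no change at the digits printed from compound 3 to compound 4 (within the scatter) in this assay and so, for the first time, isolates the nitro group: at this place on the aromatic ring, para to a large group, nitro and hydrogen cannot be told apart in this read-out, with butyl on the aromatic nitrogen. With benzyl held fixed, butyl in place of cyclopropyl gives no change at the digits printed from compound 2 to compound 4 (within the scatter) and methyl in place of hydrogen at the end of the propyl chain gives no change at the digits printed from compound 1 to compound 4 (within the scatter) and these two steps join the earlier cyclopropyl step to show that all three chains on the aromatic nitrogen sit within the scatter of one another. Nothing available accounts for this flat result.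

As far as these compounds go, the nitro step has been read only with butyl on the aromatic nitrogen, so whether it would stay as flat with propyl or cyclopropyl there remains open. The compounds shown also leave open whether an amine or a carboxylic acid on the benzyl ring, or a longer chain on the aromatic nitrogen, would move the number at all.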